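The compounds below may be only part of what the source reports. "The series", "measured", "known", "first", "only" and "open" are said of these compounds alone.

Compound 1 `CC(C)=CCOc1ccc(C(=O)/C=C/c2ccncc2)c(O)c1` and compound 2 `CC(C)=CCOc1ccc(C(=O)/C=C/c2cccnc2)c(O)c1` share one core and differ only in the pendant ring. In an ADME assay on Vero cells (Chlorocebus sabaeus) for cytotoxicity, read by resazurin assay, with a stated time of 72 h (on this read-out higher numbers stand for lower toxicity in this test and lower numbers for higher toxicity in this test), compound 1 gives 40000 nM. In this assay compound 2 gives 210000 nM. The change between them is pyridin-3-yl in place of pyridin-4-yl on a double-bonded chain carbon bound to a double-bonded chain carbon, and it made a 5.3-fold higher number from compound 1 to compound 2 (0.72 log units; beyond the scatter).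

Compound 3 `C#CCOc1ccc(C(=O)/C=C/c2ccncc2)c(OCC#C)c1` is built on another core; the difference between the core of compound 3 and the core of compound 1 is not broken down here. In this assay compound 3 gives 10000 nM, the lowest of the three numbers, and its gap to compound 1 as well as to compound 2 lies beyond the scatter.

Compound 4 `C#CCOc1ccc(C(=O)/C=C/c2cccnc2)c(OCC#C)c1` has not yet been measured. It differs from compound 3 by pyridin-3-yl in place of pyridin-4-yl on a double-bonded chain carbon bound to a double-bonded chain carbon, the same change that separates compound 1 from compound 2, made at the same place. Going by the values given here, from compound 3 to compound 4 the step in this assay is expected to be a 4.0-fold higher number from compound 3 to compound 4 (0.60 log units; beyond the scatter), set beside the earlier 5.3-fold higher number from compound 1 to compound 2 (0.72 log units; beyond the scatter) as the only measured instance of this change, with allowance for the fact that it is now carried onto a different core and that a single instance cannot show how well the shift transfers. For compound 4 the expected number in this assay is 40000 nM, within a range from 15000 nM to 120000 nM.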

Compound 4, half-maximal cytotoxic concentration: 6000 nM
Compound 4: the middle estimate sits 6.7-fold (0.82 log units) above what was measured; the measured number lies below the stated range.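

In this assay, putting pyridin-3-yl in place of pyridin-4-yl on the core of compound 3 gives a 1.7-fold lower number from compound 3 to compound 4 (0.22 log units; within the scatter), so on this core the change leaves the two compounds indistinguishable, although on the core of compound 1 it had a clear effect. The change therefore did not carry over as a fixed shift from one core to the other, and the size of the earlier step could not be applied to the new core: the same change on two cores in this assay, a 5.3-fold higher number (0.72 log units; beyond the scatter) from compound 1 to compound 2 and a 1.7-fold lower number (0.22 log units; within the scatter) from compound 3 to compound 4, 8.8-fold (0.94 log units) apart, beyond the scatter of two such steps. This shows that, for this pair of cores, the effect of the change depends on the core, but it does not show which difference between the cores is responsible, and with one step on each core it gives no general rule for how the change behaves across the series.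

The compounds shown leave open how the same change would behave on a core carrying methoxy groups or longer alkyl chains in place of the present ether chains, and so whether either measured step is the more typical. They also leave open how pyridin-2-yl or a plain phenyl ring, placed on a double-bonded chain carbon bound to a double-bonded chain carbon, would compare on the two cores.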